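From methyl to (4-methylphenyl)sulfonyl on the ring nitrogen

The compounds below may be only part of what the source reports. "The series", "measured", "known", "first", "only" and "open" are said of these compounds alone.

Values measured in a functional assay on NCI-H460 cells (Homo sapiens) for cytotoxicity, read by MTT assay, with a stated time of 3 days (on this read-out higher numbers stand for weaker inhibition and lower numbers for stronger inhibition), are as follows.

Compound 1 `N#Cc1c(NN)nc(SCc2nc3ccccc3[nH]2)nc1-c1ccccc1` gives 2.6 nM
Compound 2 `N#Cc1c(-c2ccccc2)nc(SCc2nc3ccccc3[nH]2)nc1N1CCNCC1` gives 7.35 nM
Compound 3 `CN1CCN(c2nc(SCc3nc4ccccc4[nH]3)nc(-c3ccccc3)c2C#N)CC1` gives 2.84 nM

Among the compounds with values here, compound 3 lies near the low end of the numbers measured so far, and only compound 2 is clearly higher. The steps behind this picture are a 1.1-fold higher number from compound 1 to compound 3 (0.04 log units; within the scatter) and a 2.6-fold lower number from compound 2 to compound 3 (0.41 log units; beyond the scatter) in turn.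

The next structure, compound 4 `Cc1ccc(S(=O)(=O)N2CCN(c3nc(SCc4nc5ccccc5[nH]4)nc(-c4ccccc4)c3C#N)CC2)cc1` keeps the shared core and carries (4-methylphenyl)sulfonyl in place of methyl on an amine nitrogen in a ring. The full count of this swap is (4-methylphenyl)sulfonyl in place of methyl on an amine nitrogen in a ring in all.

Within the data shown here, only one measured step changes this same nitrogen, namely a 2.6-fold lower number from compound 2 to compound 3 (0.41 log units; beyond the scatter) and it is modest. The step of a 2.8-fold higher number from compound 1 to compound 2 (0.45 log units; beyond the scatter) is also modest, at the same attachment point on the core. Among the measured compounds shown here, no measured compound has a group of this size on that nitrogen, so the guidance is thin. A modest move towards a higher number is therefore expected, with wide uncertainty. The expected change is a 1.8-fold higher number from compound 3 to compound 4 (0.25 log units; within the scatter) and it remains an estimate. For compound 4 the estimated value is 5 nM with an expected range from 1.5 nM to 20 nM on repeated measurement.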

Compound 4, half-maximal inhibitory concentration: 22.7 nM
The estimate for compound 4 lay 4.5-fold (0.66 log units) below the measured number; the whole stated range lies below it.
By their numbers in this assay, from the lowest: compounds 1 and 3 (each within the scatter of the next); then compound 2; then compound 4.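

On the ring nitrogen of the piperazine, this assay responds strongly to the new group: putting (4-methylphenyl)sulfonyl in place of methyl gives an 8.0-fold higher number from compound 3 to compound 4 (0.90 log units; beyond the scatter), the largest step among these compounds so far. Set against the free ring nitrogen, the same group also raises the number, with a 3.1-fold higher number from compound 2 to compound 4 (0.49 log units; beyond the scatter), whereas the only earlier change at this nitrogen, a 2.6-fold lower number from compound 2 to compound 3 (0.41 log units; beyond the scatter), went the opposite way. Within the data shown here, the three compounds together show that this nitrogen is not indifferent to what it carries and that a group placed there can move the number in either direction, with compound 4 at 22.7 nM the highest of the series so far.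

No measurement at hand explains why this group raises the number. Going by these compounds, it also remains open which part of (4-methylphenyl)sulfonyl matters, the sulfonyl or the aromatic ring, and what a methylsulfonyl, a benzyl or an acetyl group on the same nitrogen would give.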